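The source may hold more compounds than are shown below. What is called first, only, known or untested is meant among the compounds shown, and "the series" means these compounds.

compound 1 `Nc1ccccc1NC(=O)/C=C/c1ccc(CSc2cccc(F)c2)cc1` gives 8.25%
compound 2 `CCc1ccc(SCc2ccc(C(=O)Nc3ccccc3N)cc2)cc1` gives 82.9%
compound 3 `Nc1ccccc1NC(=O)c1ccc(CSc2ccc(Br)cc2)cc1` gives 25.3%

In a functional assay on SMMC-7721 cells (Homo sapiens) for inhibition, read by CCK-8 assay, with a stated time of 72 h, tested at 8 uM (a higher number here means more inhibition of growth at the concentration tested, a lower number less inhibition of growth), compound 1 stands lowest of the three at 8.25% and lies beyond the scatter from both others. The nearest is compound 3 at 25.3% and the furthest is compound 2 at 82.9%.

The next compound to be read is compound 4 `Nc1ccccc1NC(=O)/C=C/c1ccc(CSc2cccc3ccccc23)cc1`, which carries naphthalen-1-yl in place of 3-fluorophenyl on a sulfur.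

Within the data shown here, only one measured step bears on this change, and only indirectly. It is a number 57.6 percentage points lower from compound 2 to compound 3 (beyond the scatter), a large step beyond the scatter, with bromo in place of ethyl on an aromatic carbon. It suggests that a change in the aromatic group on the sulfur can move this assay substantially. However, compounds 2 and 3 do not share the core of compound 1, and no measured compound carries naphthalen-1-yl. Neither size nor direction therefore transfers directly.

From the low starting value of compound 1 at 8.25% a moderate rise is expected, with wide uncertainty. The expected step is a number 16.8 percentage points higher from compound 1 to compound 4 (beyond the scatter). For compound 4 the estimated value is 25%, with an estimated range from 5% to 60%.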

Compound 4, percent growth inhibition at one concentration: 18.3%
Compound 4: the middle estimate sits 6.7 percentage points above what was measured, within the range that was stated.
By their numbers in this assay, from the lowest: compound 1; then compounds 4 and 3 (each within the scatter of the next); then compound 2.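

Among these compounds, on the core of compound 1, this is the first step read at the group on the sulfur, since the earlier step between compound 2 and compound 3 lay on a different core. In this assay the step is a number 10.1 percentage points higher from compound 1 to compound 4 (beyond the scatter) and goes with the exchange of 3-fluorophenyl for naphthalen-1-yl, so a second fused aromatic ring at this place is compatible with a small gain, while compound 4 at 18.3% remains far from the high number seen for compound 2 on its own core. Nothing available explains this modest rise, and no measured property of either group bears on it.

The exchange removes the fluorine and adds a ring in one move, so the two contributions cannot be separated here; plain phenyl on the sulfur would divide them, and 4-ethylphenyl on the same core would test whether the ethyl group of compound 2 carries over. Also open, as far as these compounds go, is whether this place accepts anything other than an aromatic group, such as cyclohexyl or a short chain ending in an amine.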